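From pyridin-4-yl to cycloheptyl on the amine nitrogen

A few compounds are considered here, and "the series" means these few. Any claim that something is new, unique, unknown or untested is made for them only; others in the source may bear on it.

Measured in a functional assay on SK-OV-3 cells (Homo sapiens) for inhibition, read by CCK-8 assay, with a stated time of 70 h; a higher number here means a weaker inhibitor, a lower number a stronger inhibitor:
Compound 1 `COc1ccc(COc2ccc(OCCOCCNC3CCCC3)cc2)cc1`: 15700 nM
Compound 2 `c1ccc(COc2ccc(OCCOCCNc3ccncc3)cc2)cc1`: 20600 nM
Compound 3 `O=C(O)c1ccccc1COc1ccc(OCCOCCNC2CCCC2)cc1`: > 100000 nM, a limit of the assay

In this assay compound 2 gives 20600 nM and compound 1 gives 15700 nM, two numbers within the scatter of each other. Compound 3 has only a limit, > 100000 nM.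

Compound 4 `c1ccc(COc2ccc(OCCOCCNC3CCCCCC3)cc2)cc1` carries cycloheptyl in place of the pyridin-4-yl of compound 2 on an amine nitrogen (cycloheptyl in place of pyridin-4-yl on an amine nitrogen). Going by the values given here, the one measured step, an at least 6.3-fold higher number from compound 1 to compound 3 (0.80 log units; beyond the scatter), concerns 2-carboxyphenyl in place of 4-methoxyphenyl on a saturated chain carbon bound to an oxygen on an aromatic ring, so it does not bear on this change. The nearer guide is compound 1, which also has a non-aromatic ring of carbon only on the amine nitrogen, although it differs from compound 2 elsewhere as well. With compound 1 at 15700 nM, no step beyond the scatter is expected in this assay. The step expected is a 1.3-fold lower number from compound 2 to compound 4 (0.11 log units; within the scatter). For compound 4 the estimate is 16000 nM, with an expected range of 6000 nM to 45000 nM.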

Compound 4, half-maximal inhibitory concentration: 7460 nM
Compound 4: middle estimate off by 2.1-fold (0.33 log units), on the high side; low and high end bracket the measured number.
By their numbers in this assay, from the lowest: compound 4; then compounds 1 and 2 (each within the scatter of the next). At a limit, above all of these: compound 3.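

The amine nitrogen turns out to be a position where the group matters in this assay: with the rest of the molecule unchanged, cycloheptyl in place of pyridin-4-yl gives a 2.8-fold lower number from compound 2 to compound 4 (0.44 log units; beyond the scatter). Going by these compounds alone, the earlier compounds could not show this, since compound 1 and compound 2 differ in more than one place and the only earlier step concerned a different position. The change removes an aromatic ring bearing a nitrogen and brings in a seven-membered ring of carbon only, but nothing shown gives a cause for the step.

The compounds shown leave open whether the lower number follows from losing the ring nitrogen, losing the aromatic ring or enlarging the ring. Phenyl, piperidin-4-yl or cyclohexyl on the same amine nitrogen would separate these possibilities.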